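The source may hold more compounds than are shown below. What is called first, only, known or untested is meant among the compounds shown, and "the series" means these compounds.

Compound 2 `CCOc1ccc(C2C(Oc3ccccc3)C(=O)N2c2cc(OC)c(OC)c(OC)c2)cc1` is one of three compounds whose activity has been measured in a functional assay on MCF7 cells (Homo sapiens) for inhibition, read by resazurin assay, with a stated time of 72 h; a lower number here means a stronger inhibitor, a higher number a weaker inhibitor. Compound 2 gives 69 nM, which places it second highest of the three numbers. Compound 1 `COc1ccc(C2C(O)C(=O)N2c2cc(OC)c(OC)c(OC)c2)cc1` gives 4 nM, and compound 3 `CCSc1ccc(C2C(Oc3ccccc3)C(=O)N2c2cc(OC)c(OC)c(OC)c2)cc1` gives 210 nM. The only single-change step among these three is that a 3.0-fold higher number from compound 2 to compound 3 (0.48 log units; beyond the scatter).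

Compound 4 `CCOc1ccc(C2CC(=O)N2c2cc(OC)c(OC)c(OC)c2)cc1` has not yet been measured in this assay. It differs from compound 2 in one place: hydrogen in place of phenoxy on a saturated ring carbon. The measured step from compound 2 to compound 3 changes a group on an aromatic carbon, not on the saturated ring carbon, so it does not speak directly to this change. Compound 1 carries a hydroxyl at that saturated ring carbon and gives a lower number than compound 2, but it also differs elsewhere, so only the two values can be compared. With nothing else to go on, a modest step is expected, that is a 1.7-fold lower number from compound 2 to compound 4 (0.24 log units; within the scatter), toward a lower number. Compound 4 is therefore estimated at 40 nM, within a range from 8 nM to 200 nM.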

Compound 4, half-maximal inhibitory concentration: 64 nM
Compound 4: middle estimate off by 1.6-fold (0.20 log units), on the low side, and the stated range covers the measured number.
By their numbers in this assay, from the lowest: compound 1; then compounds 4 and 2 (each within the scatter of the next); then compound 3.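

Going by these compounds alone, this is the first single-change reading at the saturated ring carbon, and in this assay replacing phenoxy with hydrogen gives a 1.1-fold lower number from compound 2 to compound 4 (0.03 log units; within the scatter). Losing all 7 heavy atoms of phenoxy, aromatic ring included, therefore leaves the number within the scatter, so in this pair the phenoxy group is not needed to keep activity at this level, and its presence costs nothing measurable either. No measured data are available to explain this result.

Still open, on these data alone, is what a hydroxyl, an amine or a carboxylic acid would give at this saturated ring carbon with the 4-ethoxyphenyl group kept in place. Compound 1 carries a hydroxyl there but also differs in a second place, so it cannot settle the effect of that group alone.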